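The source may report more compounds than this note shows. Statements on the series, on what has been measured and on what is new or still open speak of the compounds shown alone.

Compound 1 `C[C@H](Nc1ncnc2[nH]cnc12)c1cc2ccc(F)cn2c(=O)c1-c1ccccc1` is the anchor of the series; in an ADME assay on microsomes from liver (Mus musculus), read by LC-MS, using NADPH, with a stated time of 30 min, tested at 1 uM (a lower number here means that less of the compound is left, a higher number that more of the compound is left), compound 1 gives 94%. Compound 2 `C[C@H](Nc1ccnc(N)n1)c1cc2ccc(F)cn2c(=O)c1-c1ccccc1` carries another group on the amine nitrogen, and in this assay compound 2 gives "not determined" (no result reported), so compound 2 stands on no number here. Compound 3 `Cc1nc(N)nc(N[C@@H](C)c2cc3ccc(F)cn3c(=O)c2-c2ccccc2)c1C#N` differs from compound 2 by 2-amino-5-cyano-6-methylpyrimidin-4-yl in place of 2-aminopyrimidin-4-yl on an amine nitrogen. Within the data shown here, no measured step between compound 2 and compound 3 exists, so the size and direction of this step in this assay are unknown; none beyond the scatter is assumed. Resting on compound 1 with 94%, compound 3 is expected to give 80% in this assay, estimated within 55% to 97%.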

Compound 3, percent of the compound remaining: 8%
Beside the measured number, compound 3's estimate is 72 percentage points above it; measured number outside the range, below it.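

In this assay there is a number 86 percentage points lower from compound 1 to compound 3 (beyond the scatter), with 2-amino-5-cyano-6-methylpyrimidin-4-yl in place of the two-ring group of compound 1 on the amine nitrogen. This position can therefore carry a large change in the percent of compound remaining, which compound 1 alone could not show. Nothing available accounts for this step.

Going by these compounds, the step from compound 2 to compound 3 cannot be read, so the separate shares of the nitrile and the methyl remain open. On these data alone, whether a carboxamide in place of the nitrile would give a different reading also remains open.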